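The compounds below may be only part of what the source reports. "The series", "measured", "known", "first", "only" and "open" are said of these compounds alone.

Working notes on the series.

Compound 2 `O=[N+]([O-])c1ccc(CSc2nc(NC3CC3)nc3c2ncn3[C@@H]2O[C@H](CO)[C@@H](O)[C@H]2O)cc1` in an assay on K562 cells for displacement of a labelled ligand from Equilibrative nucleoside transporter 1 (Homo sapiens), read by flow cytometry, with a stated time of 45 min (a higher number here means a weaker inhibitor, a lower number a stronger inhibitor), gives 25 nM. Within the data shown here, the only other compound measured so far is compound 1 `CNc1nc(SCc2ccc([N+](=O)[O-])cc2)c2ncn([C@@H]3O[C@H](CO)[C@@H](O)[C@H]3O)c2n1`, which in this assay gives 24 nM. Among the measured compounds shown here, the step of a 1.0-fold higher number from compound 1 to compound 2 (0.02 log units; within the scatter) is the sole measured comparison in the set, so compound 2 stands alongside compound 1 with the two numbers within the scatter of each other; no ordering between them can be claimed.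

Compound 3 `CCCCNc1nc(SCc2ccc([N+](=O)[O-])cc2)c2ncn([C@@H]3O[C@H](CO)[C@@H](O)[C@H]3O)c2n1` is not yet measured. It differs from compound 2 as butyl in place of cyclopropyl on a nitrogen on an aromatic ring. For the measured compounds named here, the one measured step that bears on this position is a 1.0-fold higher number from compound 1 to compound 2 (0.02 log units; within the scatter), a change at the same nitrogen on the aromatic ring from methyl to cyclopropyl that left the number essentially unchanged. Butyl is a longer, ringless chain than either group already tested, and no measured step covers a chain of that length, so the extrapolation rests on a single within-scatter comparison.

Accordingly the expectation for compound 3 is a step of a 1.4-fold higher number from compound 2 to compound 3 (0.15 log units; within the scatter), most likely within the scatter, with a modest lean toward a higher number given the untested length. Compound 3 is estimated at 35 nM in this assay, with a range from 14 nM to 90 nM.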

Compound 3, inhibition constant: 325 nM
For compound 3 the middle estimate is 9.3-fold (0.97 log units) below the measured one; measured number above the stated range.
By their numbers in this assay, from the lowest: compounds 1 and 2 (each within the scatter of the next); then compound 3.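

At the nitrogen on an aromatic ring, the position proves not to be indifferent to what it carries in this assay: butyl in place of cyclopropyl gives a large step (a 13-fold higher number from compound 2 to compound 3 (1.11 log units; beyond the scatter)), and butyl in place of methyl gives another (a 14-fold higher number from compound 1 to compound 3 (1.13 log units; beyond the scatter)). The earlier pair showed only that methyl and cyclopropyl could not be told apart, whereas butyl now marks a group that this position does not accept equally, and compound 3 is the weakest of the three compounds. No measurement shown here accounts for this loss.

Butyl differs from cyclopropyl both in chain length and in having no ring, so the compounds shown cannot separate these two differences, and neither ethyl, propyl nor cyclobutyl is available to show whether the number rises gradually with the chain or abruptly at butyl. Going by these compounds, it also remains open whether a chain ending in a hydroxyl or an amine would behave as butyl does, and whether the same step would appear with another group in place of the 4-nitrobenzyl on the sulfur of the shared core.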